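The source may report more compounds than this note shows. Statements on the series, on what has been measured and on what is new or still open speak of the compounds shown alone.

Working notes on the series, all on the shared core of compound 1 `O=C1C(Nc2ccc(I)cc2)=CC(=O)c2c1nc1n2[C@H]2OC[C@@H](O)[C@H]2OC1`. In a functional assay on ECa-109 cells for inhibition, with ECa-109 cell line (Homo sapiens) as the target, read by sulforhodamine B assay (a lower number here means a stronger inhibitor, a higher number a weaker inhibitor), compound 1 gives 2530 nM and compound 2 `Cc1ccc(NC2=CC(=O)c3c(nc4n3[C@H]3OC[C@@H](O)[C@H]3OC4)C2=O)cc1C` gives 4090 nM. Compound 3 `COc1ccccc1NC1=CC(=O)c2c(nc3n2[C@H]2OC[C@@H](O)[C@H]2OC3)C1=O` gives > 4000 nM, which is a limit of the assay and not a number. This is the limit of > 4000 nM in this assay, at which 1 of the 3 values shown sits.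

The next change leads to compound 4 `O=C1C(N2CCCC2)=CC(=O)c2c1nc1n2[C@H]2OC[C@@H](O)[C@H]2OC1`: pyrrolidin-1-yl in place of (2-methoxyphenyl)amino on a double-bonded ring carbon. In short, pyrrolidin-1-yl stands in place of (2-methoxyphenyl)amino on a double-bonded ring carbon.

Among the compounds with values here, three measured steps bear on this, though only indirectly: a 1.6-fold higher number from compound 1 to compound 2 (0.21 log units; within the scatter), an at least 1.5-fold higher number from compound 1 to compound 3 (0.19 log units; that floor lies within the scatter) and a step that the limit leaves unreadable from compound 2 to compound 3. Each exchanges one phenyl group on an amine nitrogen for another, and none removes the amine hydrogen or the aromatic ring as this change does. The series therefore gives no direct measure of the change, and the range must stay wide. No size or direction can be drawn from these steps, so no step beyond the scatter is expected in this assay. The expectation rests on compound 2 at 4090 nM.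

The expected step is a step that the limit leaves unreadable from compound 3 to compound 4. For compound 4 the estimated value is 4500 nM, with an expected range of 1500 nM to 14000 nM.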

Compound 4, half-maximal inhibitory concentration: > 16000 nM
Compound 4 gave a limit, no number (the forecaster's own chance of this, stated with the estimate: 35%); middle value at least 3.5-fold (0.55 log units) from the limit.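

In this assay compound 4 stands at a limit of the assay and not at a number: the limit of > 16000 nM in this assay, at which 1 of the 4 values shown sits.

Pyrrolidin-1-yl in place of (3,4-dimethylphenyl)amino gives an at least 3.9-fold higher number from compound 2 to compound 4 (0.59 log units; beyond the scatter), and in place of (4-iodophenyl)amino it gives an at least 6.3-fold higher number from compound 1 to compound 4 (0.80 log units; beyond the scatter). Within the data shown here, these are the first readable steps at this double-bonded ring carbon that lie beyond the scatter, whereas the readable exchanges of one phenyl group for another on the amine nitrogen did not. Compound 3 also stands at a limit and not at a number, so its step to compound 4 cannot be read: the limit of > 4000 nM in this assay, at which 1 of the 4 values shown sits.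

The change takes away the amine hydrogen and the six-membered aromatic ring in a single step, and the compounds shown do not separate the two, nor do they give the full size of the loss. Going by these compounds, a cyclopentylamino group would keep the amine hydrogen without the aromatic ring, a methyl(phenyl)amino group would keep the aromatic ring without the amine hydrogen, and how either reads at this position in this assay remains open.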